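The compounds below may be only part of what the source reports. "The series", "measured", "known", "first", "only" and "open" are said of these compounds alone.

In a functional assay on K562 cells (Homo sapiens) for inhibition, read by CCK-8 assay, with a stated time of 72 h (a lower number here means a stronger inhibitor, a higher number a weaker inhibitor), compound 1 (`Cc1ccc(NS(=O)(=O)c2cccc(CCCCCCNC(=O)/C=C/c3cccnc3)c2)cc1`) gives 2.98 nM and compound 2 (`Cc1ccccc1NS(=O)(=O)c1cccc(CCCCCCNC(=O)/C=C/c2cccnc2)c1`) gives 0.456 nM while compound 3 (`O=C(/C=C/c1cccnc1)NCCCCCCc1cccc(S(=O)(=O)Nc2ccc(F)cc2)c1`) gives 0.93 nM as the second highest of the three numbers. Compound 4 (`O=C(/C=C/c1cccnc1)NCCCCCCc1cccc(S(=O)(=O)Nc2ccc(C(F)(F)F)cc2)c1`) differs from compound 3 at one place (trifluoromethyl in place of fluoro on an aromatic carbon) with trifluoromethyl in place of fluoro on an aromatic carbon, para to a large group.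

The closest measured evidence is the exchange of methyl for fluoro at that carbon (a 3.2-fold lower number from compound 1 to compound 3 (0.51 log units; beyond the scatter)) which is a modest step. The changes of the whole group on the sulfonamide nitrogen are also modest (a 6.5-fold lower number from compound 1 to compound 2 (0.82 log units; beyond the scatter)) and (a 2.0-fold higher number from compound 2 to compound 3 (0.31 log units; beyond the scatter)) so nothing measured here suggests a large step. Within the data shown here, no compound carrying trifluoromethyl has been measured, which leaves the direction uncertain. The expectation leans only weakly upward and rests on compound 1, whose methyl at that carbon goes with the higher number (2.98 nM). The expected change is small and upward (a 1.9-fold higher number from compound 3 to compound 4 (0.29 log units; within the scatter)). The estimate for compound 4 is 1.8 nM with an expected range from 0.5 nM to 6 nM in this assay.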

Compound 4, half-maximal inhibitory concentration: 44.9 nM
For compound 4 the middle estimate is 25-fold (1.40 log units) below the measured one; measured number above the stated range.
By their numbers in this assay, from the lowest: compound 2; then compound 3; then compound 1; then compound 4.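

In this assay, among these compounds, the aromatic carbon para to a large group proves far less forgiving than the earlier compounds indicated: trifluoromethyl in place of fluoro gives a 48-fold higher number from compound 3 to compound 4 (1.68 log units; beyond the scatter) and trifluoromethyl in place of methyl gives a 15-fold higher number from compound 1 to compound 4 (1.18 log units; beyond the scatter) on the same carbon, whereas the exchange of methyl for fluoro there was only modest. Set against the 2-methylphenyl group on the sulfonamide nitrogen, 4-(trifluoromethyl)phenyl gives a 98-fold higher number from compound 2 to compound 4 (1.99 log units; beyond the scatter) and so opens the widest gap among the four compounds, all three steps to compound 4 being large where every earlier step was modest. Nothing available here accounts for the loss that comes with trifluoromethyl at this carbon.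

Chloro, methoxy or a nitrile at this carbon would show whether the change from fluoro to trifluoromethyl is gradual or abrupt, and whether trifluoromethyl alone stands apart. A 2-(trifluoromethyl)phenyl group on the sulfonamide nitrogen would show whether the loss belongs to this carbon or follows trifluoromethyl to another place on the ring.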